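The source may hold more compounds than are shown below. What is called first, only, known or untested is meant among the compounds shown, and "the series" means these compounds.

Compound 1 `Cc1c(S(=O)(=O)n2ccc3c(N4CCNCC4)cccc32)sc2ccc(Cl)cc12`: 3.16 nM
Compound 2 `O=S(=O)(c1cccc(Cl)c1)n1ccc2c(N3CCNCC3)cccc21`: 0.251 nM

Both were tested in an assay on HeLa cells for displacement of a labelled ligand from 5-hydroxytryptamine receptor 6 (Homo sapiens); on this read-out lower numbers stand for stronger inhibition and higher numbers for weaker inhibition. Compound 2 stands lowest of the two numbers; its nearest neighbour is compound 1, whose number is higher by a margin that lies beyond the usual scatter. Compound 3 `O=S(=O)(c1ccccn1)n1ccc2c(N3CCNCC3)cccc21` has not been measured yet. It differs from compound 2 in one place: pyridin-2-yl in place of 3-chlorophenyl on a sulfonyl sulfur. Among the compounds with values here, no pair of measured compounds shows this kind of change, so no step is known for it. The expectation is a modest shift toward a higher number, on the order of a 4.0-fold higher number from compound 2 to compound 3 (0.60 log units; beyond the scatter). For compound 3 the estimated value is 1 nM, with a range from 0.2 nM to 5 nM.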

Compound 3, inhibition constant: 1 nM
Estimate against measurement, compound 3: no gap at the digits printed, within the range that was stated.
By their numbers in this assay, from the lowest: compound 2; then compound 3; then compound 1.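

In this assay the swap to pyridin-2-yl on the sulfonyl sulfur gives a 4.0-fold higher number from compound 2 to compound 3 (0.60 log units; beyond the scatter) and leaves compound 3 at 1 nM on this read-out, so this position does not need the 3-chlorophenyl group for a number this low. The step changes two things at once, since the chlorine leaves and a ring nitrogen enters, and their shares cannot be separated. Nothing measured here explains the size of this step.

The compounds shown leave open how a plain phenyl ring, which would separate those two changes, would score, and how a pyridin-3-yl ring would compare.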